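Ethyl to 3-Bromophenyl at the Amide Nitrogen

The compounds below may be only part of what the source reports. "The series", "measured", "known", "first", "only" and "open" are said of these compounds alone.

Compound 1 `CCNC(=O)CCc1cccc2c1B(O)OC2` was tested in a functional assay on MDA-MB-231 cells (Homo sapiens) for antiproliferative activity, read by MTT assay, with a stated time of 72 h; on this read-out higher numbers stand for weaker inhibition and lower numbers for stronger inhibition. In this assay compound 1 returns only a limit, > 100000 nM, and that is where it stands, at the ceiling of the measurements (the limit of > 100000 nM in this assay, at which 2 of the 3 values shown sit). Compound 2 `C#Cc1ccc(NC(=O)CCc2cccc3c2B(O)OC3)cc1` gives 6600 nM in this assay. Compound 3 `CCOC(=O)c1ccc(NC(=O)CCc2cccc3c2B(O)OC3)cc1` returns only a limit in this assay, > 100000 nM. Among the compounds with values here, the single measured step, an at least 15-fold higher number from compound 2 to compound 3 (1.18 log units; beyond the scatter), concerns a substituent on the aromatic ring of an aryl amide and does not speak directly to exchanging an alkyl for an aryl group on the nitrogen.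

Compound 4 `O=C(CCc1cccc2c1B(O)OC2)Nc1cccc(Br)c1` differs from compound 1 by 3-bromophenyl in place of ethyl on an amide-type nitrogen. Within the data shown here, no measured step covers this exchange, and the two aryl amides among the measured compounds fall at a numbered value and at the limit, so a broad estimate is the honest one. Compound 4 is therefore expected to show an at least 5.0-fold lower number from compound 1 to compound 4 (0.69 log units; beyond the scatter). The estimated value for compound 4 is 20000 nM, within a range from 4000 nM to 100000 nM.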

Compound 4, half-maximal inhibitory concentration: 720 nM
For compound 4 the middle estimate is 28-fold (1.44 log units) above the measured one; the measured number lies below the stated range.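

Placing 3-bromophenyl in place of ethyl on the amide-type nitrogen gives, in this assay, an at least 130-fold lower number from compound 1 to compound 4 (2.14 log units; beyond the scatter), the first step shown that concerns the group on this nitrogen itself. The value of compound 1 is a limit and not a number, so this step gives a bound only: the limit of > 100000 nM in this assay, at which 2 of the 4 values shown sit. The step shows that an aromatic ring on this nitrogen can go with a far lower number, yet compound 3, which also carries an aromatic ring there, returns a limit, so such a ring alone is not enough.

As far as these compounds go, how much of the step belongs to the ring and how much to the bromine remains open, and a plain phenyl group would separate the two. From the compounds shown here alone, whether a cyclohexyl or benzyl group on this nitrogen would serve in the same way also remains open.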